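The source may hold more compounds than are shown below. What is called first, only, known or untested is meant among the compounds shown, and "the series" means these compounds.

Measured in an ADME assay on HEK293 cells (Homo sapiens) for cytotoxicity, read by luminescence, with a stated time of 72 h; a lower number here means that less compound is tolerated, a higher number that more compound is tolerated:
- Compound 1 `N#Cc1c(-c2cccc(C(F)(F)F)c2)nc(SCC(=O)Nc2nc(-c3cc(Cl)c(N)c(Cl)c3)cs2)[nH]c1=O`: 47700 nM
- Compound 2 `CCOc1cccc(-c2nc(SCC(=O)Nc3nc(-c4cc(Cl)c(N)c(Cl)c4)cs3)[nH]c(=O)c2C#N)c1`: > 50000 nM

Compound 2 gives > 50000 nM, which is a limit of the assay and not a number. Compound 2 thus stands at the limit of > 50000 nM in this assay, at which 1 of the 2 values shown sits.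

Compound 3 `COc1cccc(-c2nc(SCC(=O)Nc3nc(-c4cc(Cl)c(N)c(Cl)c4)cs3)[nH]c(=O)c2C#N)c1` is still unmeasured. It differs from compound 2 by hydrogen in place of methyl on a saturated chain carbon bound to an oxygen on an aromatic ring, which turns 3-ethoxyphenyl into 3-methoxyphenyl.

Going by the values given here, only one measured step bears on this change, and it concerns the same substituent: an at least 1.0-fold higher number from compound 1 to compound 2 (0.02 log units; that floor lies within the scatter). Its floor lies within the scatter, so it gives no sign of a large effect. No step beyond the scatter is therefore expected in this assay, and the expected change is a number no higher from compound 2 to compound 3 (the limit leaves the size open). For compound 3 the estimated value is 50000 nM, with an expected range of 30000 nM to 70000 nM.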

Compound 3, half-maximal cytotoxic concentration: > 50000 nM
Compound 3: a limit, no number (the forecaster's own chance of this, stated with the estimate: 65%); the middle value sits exactly at the limit.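

In this assay, the shorter group on the ring behaves no differently from the longer one as far as can be seen: with 3-methoxyphenyl as with 3-ethoxyphenyl, the result is a limit and not a number, so the step between compound 2 and compound 3 cannot be read. Methoxy in place of trifluoromethyl gives an at least 1.0-fold higher number from compound 1 to compound 3 (0.02 log units; that floor lies within the scatter), so this second ether, like ethoxy, shows no step beyond the scatter. The series now gathers at one end of the assay's range: the limit of > 50000 nM in this assay, at which 2 of the 3 values shown sit.

Any difference between methoxy and ethoxy stays hidden behind the limit, so the size of this change remains unknown. Also open, going by these compounds, is whether a hydroxyl group, an amine, a carboxylic acid or a longer chain such as propoxy at this place would give a readable number.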